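A few compounds are considered here, and "the series" means these few. Any claim that something is new, unique, unknown or untested is made for them only; others in the source may bear on it.

Measured in a toxicity assay on microsomes from liver (Homo sapiens) for metabolic stability, read by LC-MS, using NADPH, tested at 1 uM; a higher number here means faster removal of the compound, a lower number slower removal:

- Compound 1 `C[C@@H]1CN(c2sc(C3COC3)nc2-c2nc3ccccc3[nH]2)CCN1C(=O)Cn1cnc2cccnc21`: 38 mL.min-1.g-1
- Compound 2 `CCOc1ncc(-c2nc(C(F)(F)F)sc2N2CCN(C(=O)Cn3cnc4ccccc43)[C@H](C)C2)cn1`: 662 mL.min-1.g-1

Compound 2 stands at the top of these two at 662 mL.min-1.g-1, and compound 1 lies well under it, a gap beyond the usual scatter of this assay. Among the compounds with values here, the two structures differ in more than one place, so no single change can be read from that gap, and no measured pair gives a direct precedent for what comes next.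

Compound 3 `CCOc1ncc(-c2nc(C(F)(F)F)sc2N2CCN(C(=O)Cn3nc(C)nc3C)[C@H](C)C2)cn1` keeps the rest of compound 2 and differs on a saturated chain carbon bound to a carbonyl carbon: 3,5-dimethyl-1H-1,2,4-triazol-1-yl in place of 1H-benzimidazol-1-yl on a saturated chain carbon bound to a carbonyl carbon. A fall is the likelier direction, since compound 2 sits so high and compound 1 at 38 mL.min-1.g-1 shows that much slower removal occurs among these structures. Within the data shown here, this support is thin, resting on only two values. The expected change is a 3.0-fold lower number from compound 2 to compound 3 (0.48 log units; beyond the scatter), a fall estimated to lie probably, though not certainly, beyond the scatter. Compound 3 is expected at 220 mL.min-1.g-1, with an estimated range from 80 mL.min-1.g-1 to 550 mL.min-1.g-1.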

Compound 3, intrinsic clearance in microsomes: < 10 mL.min-1.g-1
Compound 3 was reported as a limit; the forecaster's own chance of this, stated with the estimate: 2%; at least 22-fold (1.34 log units) between middle value and limit.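

In this assay, 3,5-dimethyl-1H-1,2,4-triazol-1-yl in place of 1H-benzimidazol-1-yl on a saturated chain carbon bound to a carbonyl carbon gives an at least 66-fold lower number from compound 2 to compound 3 (1.82 log units; beyond the scatter), with the rest of the structure unchanged. This is the first comparison among these compounds in which only one place differs, and it shows that this position alone can move the read-out by a large amount, which the gap between compound 1 and compound 2 could not show. The value of compound 3 is a limit of the assay and not a number, so the step is printed as a minimum: the limit of < 10 mL.min-1.g-1 in this assay, at which 1 of the 3 values shown sits.

The change swaps one whole group for another, so the compounds shown do not separate the loss of the six-membered aromatic ring of carbon from the gain of the third ring nitrogen or the arrival of the two methyl groups. On these data alone, whether a plain 1H-1,2,4-triazol-1-yl or a 1H-imidazol-1-yl at this place would give a similar number stays open, as does whether the same exchange would have a similar effect on the rest of compound 1.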